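Methyl shift on the pyridine: compound 2 to compound 3

The source may hold more compounds than are shown below. What is called first, only, known or untested is meant among the compounds shown, and "the series" means these compounds.

Values in a physicochemical assay for lipophilicity, read by HPLC, at pH 7.4; on this read-out lower numbers stand for lower lipophilicity and higher numbers for higher lipophilicity:
- compound 1 `COCCOc1cc2oc(=O)n(CCC(=O)O)c2cc1Cl`: 0.88
- compound 2 `Cc1ccc([C@@H](C)Oc2cc3oc(=O)n(CCC(=O)O)c3cc2Cl)nc1`: 2.02

Compound 2 holds the higher of the two numbers, and its gap to compound 1 lies beyond the usual scatter. Compound 3 `Cc1cccc([C@@H](C)Oc2cc3oc(=O)n(CCC(=O)O)c3cc2Cl)n1` has not yet been measured. It differs from compound 2 as follows: 6-methylpyridin-2-yl in place of 5-methylpyridin-2-yl on a saturated chain carbon bound to an oxygen on an aromatic ring and a saturated chain carbon. In words, 6-methylpyridin-2-yl stands in place of 5-methylpyridin-2-yl on a saturated chain carbon bound to an oxygen on an aromatic ring and a saturated chain carbon.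

Among the compounds with values here, no measured pair shows a change of this kind, so the expectation rests on compound 2 at 2.02 and on the two compounds having the same atoms. No step beyond the scatter is expected in this assay. The expected change is a number 0.08 log units higher from compound 2 to compound 3 (within the scatter). For compound 3 the estimated value is 2.1, with an expected range from 1.75 to 2.45.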

Compound 3, distribution coefficient: 2.12
Estimate against measurement, compound 3: 0.02 log units below; measured number inside the range.
By their numbers in this assay, from the lowest: compound 1; then compounds 2 and 3 (each within the scatter of the next).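

Within the data shown here, this is the first pair that differs in one place, and that place is the saturated chain carbon bound to an oxygen on an aromatic ring and a saturated chain carbon. In this assay, 6-methylpyridin-2-yl in place of 5-methylpyridin-2-yl gives a number 0.10 log units higher from compound 2 to compound 3 (within the scatter) so this read-out does not separate these two methylpyridinyl groups at this place. No other data here bear on this result.

As far as these compounds go, how an unsubstituted pyridin-2-yl, a 4-methylpyridin-2-yl or a phenyl would read at this place remains open, as does the opposite configuration at the saturated chain carbon. Also open, from the compounds shown here alone, is whether compound 2 and compound 3 stay this close in any other read-out.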